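Removing a Fluorine: Cytotoxicity in Mouse Fibroblasts

This account rests on a few compounds, and the source may have more. Where it says the series, first, only, none or still open, it means among the compounds named here.

Of the compounds shown here, two of one series have been tested in an ADME assay on NIH3T3 cells (Mus musculus) for cytotoxicity, read by MTT assay, with a stated time of 24 h; a lower number here means a stronger inhibitor, a higher number a weaker inhibitor. Compound 1, `Cc1nnc(SCC(=O)N/N=c2/scc(-c3ccccc3)n2-c2ccccc2)s1`, gives 197 ug/mL in this assay. Compound 2, `O=C(CSc1nnnn1-c1ccccc1)N/N=c1/scc(-c2ccc(F)cc2)n1-c1ccccc1`, gives 207 ug/mL in this assay. Among the compounds with values here, compound 2 thus carries the higher of the two numbers, but its only neighbour is compound 1, and the gap between them lies within the scatter of repeated measurements, so the two values cannot be told apart.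

Compound 3, `O=C(CSc1nnnn1-c1ccccc1)N/N=c1/scc(-c2ccccc2)n1-c1ccccc1`, has not yet been measured in this assay. It differs from compound 2 in a single place: hydrogen in place of fluoro on an aromatic carbon. Cut one bond further out, the same difference reads 4-fluorophenyl to phenyl. Within the data shown here, no measured pair in this set shows this change, so there is no measured step to lean on. Because compound 1 at 197 ug/mL and compound 2 at 207 ug/mL sit within the scatter of each other despite differing elsewhere, the present change is expected to produce no step beyond the scatter in either direction. Compound 3 is therefore expected to give about 200 ug/mL, with a range from 120 ug/mL to 330 ug/mL. The step of a 1.0-fold lower number from compound 2 to compound 3 (0.01 log units; within the scatter) that this estimate implies is expected to be small.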

Compound 3, half-maximal inhibitory concentration: 417 ug/mL
Compound 3: middle estimate off by 2.1-fold (0.32 log units), on the low side; measured number outside the range, above it.
By their numbers in this assay, from the lowest: compounds 1, 2 and 3 (each within the scatter of the next, the first and the last beyond it).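

In this assay, the change from 4-fluorophenyl to phenyl gives a 2.0-fold higher number from compound 2 to compound 3 (0.30 log units; within the scatter), so this single replacement of fluoro by hydrogen, on an aromatic carbon para to a large group, does not by itself separate the two compounds. With the phenyl held constant, 1-phenyl-1H-tetrazol-5-yl in place of 5-methyl-1,3,4-thiadiazol-2-yl on the sulfur gives a 2.1-fold higher number from compound 1 to compound 3 (0.33 log units; beyond the scatter), a modest step and the only one here that clears the scatter; compound 1 and compound 2 had looked alike, but they differ in two places, and compound 3 lets each place be read on its own. The data offer no measurement that would account for either step.

With only fluoro and hydrogen seen at this position, the compounds leave open how a chlorine, a methoxy group or an amine there would read in this assay. They also leave open whether the step on the sulfur would hold with 4-fluorophenyl in place of phenyl, and how a group such as a carboxylic acid or a longer chain on that sulfur would compare.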